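The source may hold more compounds than are shown below. What is called first, only, known or untested is meant among the compounds shown, and "the series" means these compounds.

In a functional assay on MIA PaCa-2 cells (Homo sapiens) for antiproliferative activity (a lower number here means that less compound is needed, a higher number that more compound is needed for the effect), compound 1 `Cc1cc2c(C(N)=O)cccc2n1-c1nc2c(c(NCc3ccccc3)n1)COCC2` gives 146 nM, compound 3 `C#CCNC(=O)c1cccc2c1cc(C)n2-c1nc2c(c(NCc3ccccc3)n1)COCC2` gives 1080 nM and compound 2 `C#CCCNC(=O)c1cccc2c1cc(C)n2-c1nc2c(c(NCc3ccccc3)n1)CCCC2` gives 1410 nM. Compound 2 therefore lies within the scatter of compound 3, and its number is well above that of compound 1. The next structure, compound 4 `C#CC(=O)Nc1cccc2c1cc(C)n2-c1nc2c(c(NCc3ccccc3)n1)CCCC2`, differs from compound 2 as follows: a group of 5 heavy atoms (3 carbon, 1 nitrogen, 1 oxygen; no ring) in place of a group of 7 heavy atoms (5 carbon, 1 nitrogen, 1 oxygen; no ring), on an aromatic carbon. Among the compounds with values here, only one measured step bears on this change: a 7.4-fold higher number from compound 1 to compound 3 (0.87 log units; beyond the scatter), a modest step beyond the scatter, in which propargyl replaced hydrogen on an amide-type nitrogen. That step suggests that a smaller group on the amide may go with a lower number. Within the data shown here, it is only a loose guide, however, as no measured compound carries the (ethynylcarbonyl)amino group on the aromatic carbon. A small lowering is therefore expected, with a 1.9-fold lower number from compound 2 to compound 4 (0.27 log units; within the scatter) as the estimated step, and this is not expected to exceed the scatter. The estimate for compound 4 is 750 nM, with an expected range from 150 nM to 3000 nM.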

Compound 4, half-maximal effective concentration: 131 nM
Compound 4: middle estimate off by 5.7-fold (0.76 log units), on the high side; measured number outside the range, below it.
By their numbers in this assay, from the lowest: compounds 4 and 1 (each within the scatter of the next); then compounds 3 and 2 (each within the scatter of the next).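

On the aromatic carbon ortho to a fused ring, replacing the seven-heavy-atom group with (ethynylcarbonyl)amino gives an 11-fold lower number from compound 2 to compound 4 (1.03 log units; beyond the scatter) in this assay. The earlier step showed only a substitution on the amide nitrogen, whereas this one shows that the number at this position can shift markedly even though the counted donors, acceptors, double bonds and triple bonds stay the same; the leaving group is joined through its carbonyl and the entering group through its nitrogen. No evidence available here explains the shift.

On these data alone, whether the triple bond plays a part stays open, as a propanoylamino or acetylamino group would test at the same carbon. As far as these compounds go, it is also open whether the shorter chain or the reversed attachment of the amide accounts for the step.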